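Amino for Hydroxy, Repeated on a Second Core

The source may hold more compounds than are shown below. What is called first, only, known or untested is meant among the compounds shown, and "the series" means these compounds.

Three compounds have been measured in a functional assay on HCT-8 cells (Homo sapiens) for antiproliferative activity, read by MTT assay, with a stated time of 48 h; on this read-out lower numbers stand for stronger inhibition and higher numbers for weaker inhibition:

Compound 1 `COc1ccc(C(=O)c2ccc3c(c2)C=CC(C)(C)O3)c(NC(=O)CO)c1`: 250 nM
Compound 2 `COc1ccc(C(=O)c2ccc3c(c2)C=CC(C)(C)O3)c(NC(=O)CN)c1`: 490 nM
Compound 3 `C=C(c1ccc(OC)cc1NC(=O)CO)c1ccc(OC)c2c1OC(C)(C)C=C2`: 130 nM

Compound 2 differs from compound 1 by amino in place of hydroxy on a saturated chain carbon bound to a carbonyl carbon, and this change gave a 2.0-fold higher number from compound 1 to compound 2 (0.29 log units; within the scatter). Compound 4 `C=C(c1ccc(OC)cc1NC(=O)CN)c1ccc(OC)c2c1OC(C)(C)C=C2` has not yet been measured; it differs from compound 3 by amino in place of hydroxy on a saturated chain carbon bound to a carbonyl carbon, the same change on a different core. How the core of compound 3 differs from the core of compound 1 is not broken down here. For the measured compounds named here, because the one measured instance of this change, a 2.0-fold higher number from compound 1 to compound 2 (0.29 log units; within the scatter), stayed within the scatter, a similar step, a 2.0-fold higher number from compound 3 to compound 4 (0.30 log units; within the scatter), is expected from compound 3 to compound 4 in this assay. Compound 4 is therefore estimated at 260 nM, most likely between 130 nM and 520 nM.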

Compound 4, half-maximal inhibitory concentration: 190 nM
The estimate for compound 4 lay 1.4-fold (0.14 log units) above the measured number, and the stated range covers the measured number.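

On the second core, amino in place of hydroxy gives a 1.5-fold higher number from compound 3 to compound 4 (0.16 log units; within the scatter) in this assay. The two cores agree on this change: the same change on two cores in this assay, a 2.0-fold higher number (0.29 log units; within the scatter) from compound 1 to compound 2 and a 1.5-fold higher number (0.16 log units; within the scatter) from compound 3 to compound 4, 1.3-fold (0.13 log units) apart, within the scatter of two such steps. In these two pairs, then, the swap carries from one core to the other with neither step exceeding the usual scatter of repeat measurements, but two pairs cannot show that it would hold on further cores, and they give no reason for the agreement.

The compounds shown leave open how a methylamino group, a dimethylamino group or a carboxylic acid would read at this same place on either core. They also leave open what a longer chain carrying the hydroxy or amino group would give.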